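A few compounds are considered here, and "the series" means these few. Any claim that something is new, unique, unknown or untested is made for them only; others in the source may bear on it.

Compound 1 `CC1CCN(C2CCN(S(=O)(=O)c3cccc(Br)c3)CC2)CC1`: 3.2 nM
Compound 2 `Cc1ccc(-c2cccc(S(=O)(=O)N3CCC(N4CCC(C)CC4)CC3)c2)cc1`: 11 nM
Compound 3 `CC1CCN(C2CCN(S(=O)(=O)c3cccc(-c4ccc(Cl)cc4)c3)CC2)CC1`: 15 nM

These three compounds share one core and were all tested in a functional assay on DLD-1 cells (Homo sapiens) for antiproliferative activity, read by CellTiter-Glo, with a stated time of 72 h; a lower number here means a stronger inhibitor, a higher number a weaker inhibitor. Compound 1 gives the lowest number of the three, so it is the strongest inhibitor shown: the nearest neighbour is a 3.4-fold higher number from compound 1 to compound 2 (0.54 log units; beyond the scatter), the furthest a 4.7-fold higher number from compound 1 to compound 3 (0.67 log units; beyond the scatter). Compound 2 and compound 3 lie within the scatter of each other, a 1.4-fold higher number from compound 2 to compound 3 (0.13 log units; within the scatter).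

Compound 4 `Cc1nc(Cl)sc1S(=O)(=O)N1CCC(N2CCC(C)CC2)CC1` has not yet been measured. It differs from compound 1 in one place: 2-chloro-4-methyl-1,3-thiazol-5-yl in place of 3-bromophenyl on a sulfonyl sulfur. The two measured steps from compound 1 each swapped only the bromo on the 3-bromophenyl group for a larger ring-bearing group, and both weakened the inhibitor modestly. Among the measured compounds shown here, the step to compound 4 exchanges the whole 3-bromophenyl group for a different ring, so no measured step covers it directly; what is known is that both changes made to that group cost some potency. A modest weakening is therefore expected, with wide uncertainty, a 2.5-fold higher number from compound 1 to compound 4 (0.40 log units; beyond the scatter). For compound 4 the estimate is 8 nM, expected to fall between 2.5 nM and 25 nM.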

Compound 4, half-maximal inhibitory concentration: 1.6 nM
Estimate against measurement, compound 4: 5.0-fold (0.70 log units) above, and the stated range ends above it.
By their numbers in this assay, from the lowest: compounds 4 and 1 (each within the scatter of the next); then compounds 2 and 3 (each within the scatter of the next).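

In this assay, among the compounds shown here, the earlier compounds altered only the bromo on the 3-bromophenyl group, and each such change gave a higher number. The new step replaces the entire group and is a 2.0-fold lower number from compound 1 to compound 4 (0.30 log units; within the scatter), which shows that a six-membered aromatic ring of carbon only is not required on the sulfonyl sulfur, as the five-membered 2-chloro-4-methyl-1,3-thiazol-5-yl ring serves equally well in this assay. No measurement at hand gives a reason for this match between two different rings.

The compounds shown do not separate what the chloro and the methyl of the new ring each contribute. They also leave open how this ring would fare if it carried an amine or a carboxylic acid in place of the chloro.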